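The compounds below may be only part of what the source reports. "The series", "measured", "known", "first", "only" and "open" are said of these compounds alone.

Compound 1, whose structure is `CSc1nc(NCCCc2ccccc2)c2ccccc2n1`, was tested in a functional assay on MCF7 cells (Homo sapiens) for cytotoxicity, read by MTT assay, with a stated time of 72 h; on this read-out higher numbers stand for lower toxicity in this test and lower numbers for higher toxicity in this test. In this assay compound 1 reaches only the limit of > 100000 nM, which is a limit of the assay and not a measured number. A second compound of the shared core, compound 2, with the structure `Sc1nc(NCc2ccccc2)c2ccccc2n1`, belongs to the same set. In this assay compound 2 likewise gives > 100000 nM, again a limit rather than a number. Compound 1 thus stands on no numbered value at all: it sits at the limit of > 100000 nM in this assay, at which 2 of the 2 values shown sit, so no order between the two can be read from what has been shown.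

The next compound, compound 3, has the structure `CSc1nc(NCCCCCO)c2ccccc2n1`. It differs from compound 1 in one place: 2-hydroxyethyl in place of phenyl on a saturated chain carbon, three bonds along the chain from a nitrogen on an aromatic ring. Going by the values given here, no step between measured compounds is available to guide an expectation for this change. With both known compounds sitting at a limit, compound 3 is expected to show no shift beyond the scatter, the estimated step from compound 1 to compound 3 being a step that the limit leaves unreadable from compound 1 to compound 3. Compound 3 is therefore estimated at 150000 nM in this assay, within a range from 50000 nM to 500000 nM.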

Compound 3, concentration lethal to 50% of the cells: > 100000 nM
Compound 3 was reported as a limit; the forecaster's own chance of this, stated with the estimate: 80%; the middle value lies beyond the limit too.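

No step from compound 1 to compound 3 can be read in this assay, because both compounds give a limit of the assay and not a number: the limit of > 100000 nM in this assay, at which 3 of the 3 values shown sit.

The compounds shown leave open whether any compound of the shared core reaches a numbered value in this assay, and so how phenyl and 2-hydroxyethyl compare in this place.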